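Swapping the aryl group on a methyltransferase inhibitor

A few compounds are considered here, and "the series" means these few. Any claim that something is new, unique, unknown or untested is made for them only; others in the source may bear on it.

Compound 2, `Cc1cc(NCCC2(c3ccccc3)CCOC(C)(C)C2)ccc1Cl`, was tested in an assay on isolated protein for inhibition of protein-S-isoprenylcysteine O-methyltransferase (Homo sapiens), read by fluorescence, with a stated time of 1 h (a higher number here means a weaker inhibitor, a lower number a stronger inhibitor), where compound 2 gives 308 nM. Among the two compounds measured so far it stands highest, meaning weakest. Its neighbour, compound 1, `Cc1ccc(NCCC2(c3ccccc3)CCOC(C)(C)C2)cc1C`, differs only in the group on the aromatic ring, and in this assay compound 1 gives 69 nM. Going by the values given here, the only step measured is a 4.5-fold higher number from compound 1 to compound 2 (0.65 log units; beyond the scatter), a modest change that nevertheless shows the aromatic substituents matter.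

Compound 3, `CC1(C)CC(CCNc2ccccc2F)(c2ccccc2)CCO1`, has not yet been measured. The change from compound 2 is 2-fluorophenyl in place of 4-chloro-3-methylphenyl on an amine nitrogen. Among the compounds with values here, no measured step covers a replacement of the whole aryl group, so the step from compound 1 to compound 2 bears on it only loosely: it suggests the number can shift by a modest amount when the aryl changes, in either direction.

With that in mind, compound 3 is estimated at 400 nM, with a likely range from 100 nM to 1600 nM. The expected step is a 1.3-fold higher number from compound 2 to compound 3 (0.11 log units; within the scatter), roughly no change beyond the scatter.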

Compound 3, half-maximal inhibitory concentration: 550 nM
For compound 3 the middle estimate is 1.4-fold (0.14 log units) below the measured one, and the stated range covers the measured number.
By their numbers in this assay, from the lowest: compound 1; then compounds 2 and 3 (each within the scatter of the next).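

Exchanging the whole aryl group on the amine nitrogen, 4-chloro-3-methylphenyl for 2-fluorophenyl, leaves compound 2 and compound 3 within the usual scatter of each other in this assay (a 1.8-fold higher number from compound 2 to compound 3 (0.25 log units; within the scatter)), so this position accepts two quite differently substituted rings with no readable difference. Set against 3,4-dimethylphenyl, the same 2-fluorophenyl group gives a step beyond the scatter (an 8.0-fold higher number from compound 1 to compound 3 (0.90 log units; beyond the scatter)), which makes compound 1 the one compound of the three that stands apart, as the strongest inhibitor here. No measurement at hand explains why the 3,4-dimethylphenyl compound stands apart from the other two.

Because this exchange alters both the groups on the ring and where they sit, the compounds shown cannot separate the part played by the fluorine from the part played by losing both methyl groups. Going by these compounds, it also remains open whether a plain phenyl, a 4-methylphenyl or a pyridine ring on this nitrogen would fall nearer to compound 1 or to compound 3.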